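This account rests on a few compounds, and the source may have more. Where it says the series, first, only, none or still open, it means among the compounds named here.

Measured compounds in the series:

compound 1, `Cc1ccc(/C=C2\CCCC(CN(C)c3ccc(C)cc3)C2=O)cc1`, 27.6%
compound 2, `Cc1ccc(/C=C2\CCCC(CN(C)c3cccc(C)c3)C2=O)cc1`, 35.4%
compound 3, `Cc1ccc(N(C)CC2CCC/C(=C\c3ccc(S(C)(=O)=O)cc3)C2=O)cc1`, 27%

All three were tested in a functional assay on the whole organism (Ear, strain Kunming) for inhibition, with Mus musculus as the target, with stated times of 1 h and 30 min, at a dose of 200 mg/kg by the oral route; a lower number here means less inhibition, a higher number more inhibition at the dose given (going by the name of the read-out). Compound 1 gives 27.6% in this assay. Compound 2 differs from compound 1 by 3-methylphenyl in place of 4-methylphenyl on an amine nitrogen; in this assay compound 2 gives 35.4%, the step being a number 7.8 percentage points higher from compound 1 to compound 2 (within the scatter). Compound 3 differs from compound 1 by methylsulfonyl in place of methyl on an aromatic carbon; in this assay compound 3 gives 27%, a step of a number 0.6 percentage points lower from compound 1 to compound 3 (within the scatter). Compound 3 and compound 2 have not been compared as a pair of neighbours; their two values stand within the scatter of each other, so no order between them is claimed.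

Compound 4, `Cc1cccc(N(C)CC2CCC/C(=C\c3ccc(S(C)(=O)=O)cc3)C2=O)c1`, has not yet been measured in this assay. It differs from compound 3 by 3-methylphenyl in place of 4-methylphenyl on an amine nitrogen. This is the same change already seen between compound 1 and compound 2, made here on the core of compound 3; the surroundings of the place are the same in both pairs. Among the compounds with values here, the only guide to its size is the step of a number 7.8 percentage points higher from compound 1 to compound 2 (within the scatter), which lies within the scatter. The expectation for compound 4 is a step of a number 6 percentage points higher from compound 3 to compound 4 (within the scatter) from compound 3, resting on that one earlier step. The estimate for compound 4 in this assay is therefore 33%, with a likely range from 20% to 46%, and a measured number rather than a limit is expected.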

Compound 4, a percentage reported as inhibition, in the whole organism at one dose (the size of the read-out at that dose, not a potency): 36.7%
Estimate against measurement, compound 4: 3.7 percentage points below; the range from low to high includes it.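

In this assay, 3-methylphenyl in place of 4-methylphenyl on the amine nitrogen, now carried onto the methylsulfonyl-bearing core, gives a number 9.7 percentage points higher from compound 3 to compound 4 (within the scatter), and the two steps for this change agree across the cores: the same change on two cores in this assay, a number 7.8 percentage points higher (within the scatter) from compound 1 to compound 2 and a number 9.7 percentage points higher (within the scatter) from compound 3 to compound 4, 1.9 percentage points apart, within the scatter of two such steps

Methylsulfonyl in place of methyl on an aromatic carbon, read on the core carrying 3-methylphenyl, gives a number 1.3 percentage points higher from compound 2 to compound 4 (within the scatter), and this change also agrees across the cores: the same change on two cores in this assay, a number 0.6 percentage points lower (within the scatter) from compound 1 to compound 3 and a number 1.3 percentage points higher (within the scatter) from compound 2 to compound 4, 1.9 percentage points apart, within the scatter of two such steps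

The four compounds are thus consistent with each change carrying from one core to the other, but every step lies within the scatter, so neither change is shown to alter inhibition at all, and the agreement between steps this small, resting on a single pair of cores for each change, does not establish additivity in the wider series.

As far as these compounds go, whether a chloro or methoxy group in place of the methyl on either aromatic ring, or an ethyl group in place of the methyl on the amine nitrogen, would give a step beyond the scatter stays open. The read-out is also taken at one dose, so it gives the size of the inhibition at that dose and leaves the potency of these compounds open.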